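The source may hold more compounds than are shown below. What is called first, only, known or untested is meant among the compounds shown, and "the series" means these compounds.

Compound 1 `Cc1ccccc1NS(=O)(=O)c1ccc(N2CCNC2=O)cc1`: in a functional assay on M21 cells (Homo sapiens) for antiproliferative activity, read by sulforhodamine B assay, with a stated time of 48 h (on this read-out higher numbers stand for weaker inhibition and lower numbers for stronger inhibition), compound 1 gives 150 nM.
Compound 2 `CC(C)Cc1ccc(NS(=O)(=O)c2ccc(N3CCNC3=O)cc2)cc1`: in this assay compound 2 gives only a limit of the assay, > 1000 nM.

Compound 1 thus holds the only real number shown; the remaining value is a limit (the limit of > 1000 nM in this assay, at which 1 of the 2 values shown sits). Compound 3 `O=C1NCCN1c1ccc(S(=O)(=O)Nc2cccc(Cl)c2)cc1` differs from compound 1 in a single place (3-chlorophenyl in place of 2-methylphenyl on a sulfonamide nitrogen). Among the compounds with values here, no step between two measured compounds is known here, so the size of this change in this assay is open; a modest loss, or no change beyond the usual scatter, seems the likeliest outcome. Compound 3 is expected near 300 nM, in a range from 80 nM to 1500 nM, which means an expected step of a 2.0-fold higher number from compound 1 to compound 3 (0.30 log units; within the scatter).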

Compound 3, half-maximal inhibitory concentration: 25 nM
Compound 3: middle estimate off by 12-fold (1.08 log units), on the high side, and the stated range ends above it.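

Within the data shown here, replacing 2-methylphenyl with 3-chlorophenyl on a sulfonamide nitrogen gives the first readable step at this position in this assay: a 6.0-fold lower number from compound 1 to compound 3 (0.78 log units; beyond the scatter). Both groups have the same heavy-atom count, so that count alone does not set the value here. Steps involving compound 2 cannot be read, as its value is a limit: the limit of > 1000 nM in this assay, at which 1 of the 3 values shown sits.

The compounds shown do not separate the loss of the methyl from the gain of the chlorine. Going by these compounds, how 3-methylphenyl or 2-chlorophenyl would compare remains open, so neither the group's identity nor its place on the ring can yet be singled out.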